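From Compound 2 to Compound 4: An Expected Step

The source may hold more compounds than are shown below. What is called first, only, known or untested is meant among the compounds shown, and "the series" means these compounds.

In a functional assay on HepG2 cells (Homo sapiens) for inhibition, read by MTT assay, with a stated time of 48 h (a lower number here means a stronger inhibitor, a higher number a weaker inhibitor), compound 1 (`COc1ccc(N(C)c2nc(C)nc3ccccc23)cc1C(=O)OCC[Se]C#N`) gives 890 nM, compound 2 (`COc1ccc(N(C)c2nc(C)nc3ccccc23)cc1C(=O)OCCCC[Se]C#N`) gives 975 nM and compound 3 (`COc1ccc(N(C)c2nc(C)nc3ccccc23)cc1C(=O)OCCCCCC[Se]C#N`) gives 2650 nM. Compound 2 thus stands level with compound 1, as a 1.1-fold higher number from compound 1 to compound 2 (0.04 log units; within the scatter) shows, and below compound 3, as a 2.7-fold higher number from compound 2 to compound 3 (0.43 log units; beyond the scatter) shows. Compound 4 (`COc1ccc(N(C)c2nc(C)nc3ccccc23)cc1OCCCCC[Se]C#N`) differs from compound 2 in one place: a group of 9 heavy atoms (6 carbon, 1 nitrogen, 1 oxygen, 1 selenium; no ring) in place of a group of 10 heavy atoms (6 carbon, 1 nitrogen, 2 oxygen, 1 selenium; no ring), on an aromatic carbon, ortho to a methoxy group. Among the compounds with values here, no measured step covers this kind of change. The nearest guides are the chain steps, the largest being the modest 3.0-fold higher number from compound 1 to compound 3 (0.47 log units; beyond the scatter). A small step towards a higher number is therefore expected, estimated as a 1.3-fold higher number from compound 2 to compound 4 (0.12 log units; within the scatter). Compound 4 is expected at about 1300 nM, with an estimated range of 450 nM to 3800 nM.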

Compound 4, half-maximal inhibitory concentration: 5210 nM
For compound 4 the middle estimate is 4.0-fold (0.60 log units) below the measured one; measured number outside the range, above it.
By their numbers in this assay, from the lowest: compounds 1 and 2 (each within the scatter of the next); then compounds 3 and 4 (each within the scatter of the next).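

In this assay, the change on the aromatic carbon, where the carbonyl-bearing group gives way to one without a double bond, brings a 5.3-fold higher number from compound 2 to compound 4 (0.73 log units; beyond the scatter) and also a 5.9-fold higher number from compound 1 to compound 4 (0.77 log units; beyond the scatter). Within the data shown here, the earlier compounds kept the carbonyl and varied only the chain, so this is the first sign that the link itself can move the number beyond the scatter. No evidence is at hand to explain this step. Chain and link change together here. On these data alone, their shares stay apart; how an amide link would behave with this chain remains open.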